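Replacing the pyrimidinyl cap on the chroman series

A few compounds are considered here, and "the series" means these few. Any claim that something is new, unique, unknown or untested is made for them only; others in the source may bear on it.

Compound 3 `c1cnc(NCCCNCC2CCc3ccccc3O2)nc1`: 1.59 nM
Compound 1 `COc1cccc2c1OC(CNCCCNC1=NCCCN1)CC2`: 0.794 nM
Compound 2 `c1ccc2c(c1)CCC(CNCCCNC1=NCCCN1)C2`: 39.8 nM

In an assay on isolated protein (Bos taurus) with 5-hydroxytryptamine receptor 1D (Homo sapiens) as the target (on this read-out higher numbers stand for weaker inhibition and lower numbers for stronger inhibition), compound 3 sits second highest among the three numbers; compound 1 lies within the scatter of it, while compound 2 lies well beyond, with a much higher number. Compound 4 `c1ccc2c(c1)CCC(CNCCCNC1=NCCCC1)O2` has not been measured. It differs from compound 3 by a group of 6 heavy atoms (5 carbon, 1 nitrogen; one six-membered non-aromatic ring with 1 hetero atom) in place of a group of 6 heavy atoms (4 carbon, 2 nitrogen; one six-membered aromatic ring with 2 hetero atoms), on an amine nitrogen. Among the compounds with values here, no step between measured compounds isolates this change, and the remaining pair, compound 1 against compound 2, alters the core as well. The step from compound 3 to compound 4 in this assay is therefore expected to be small, in either direction, and not clearly beyond the scatter, a 1.9-fold higher number from compound 3 to compound 4 (0.28 log units; within the scatter). Compound 4 is estimated at 3 nM, within 0.8 nM to 12 nM.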

Compound 4, half-maximal inhibitory concentration: 3.98 nM
For compound 4 the middle estimate is 1.3-fold (0.12 log units) below the measured one; low and high end bracket the measured number.
By their numbers in this assay, from the lowest: compounds 1 and 3 (each within the scatter of the next); then compound 4; then compound 2.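

In this assay, within the data shown here, placing the non-aromatic ring with one hetero atom on the amine nitrogen, in place of pyrimidin-2-yl, gives a 2.5-fold higher number from compound 3 to compound 4 (0.40 log units; beyond the scatter), the first isolated reading of this change. The aromatic ring at this position can therefore be replaced at a modest, though real, cost in this pair. Nothing available explains the step. From the compounds shown here alone, whether a plain phenyl ring or an open guanidine on this amine nitrogen would keep the number in this assay remains open, as does how any such replacement behaves on another core.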